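This account rests on a few compounds, and the source may have more. Where it says the series, first, only, none or still open, it means among the compounds named here.

Measured compounds

- Compound 1, `CCCNC(=S)Nc1cccc(OCCCCCc2ccccc2)c1`: 32000 nM
- Compound 2, `NC(=S)Nc1cccc(OCCCCCOc2cccc(-c3ccccc3)c2)c1`: 13000 nM

In an ADME assay on Ava5 cells (Homo sapiens) for cytotoxicity (a lower number here means that less compound is tolerated, a higher number that more compound is tolerated), compound 2 gives 13000 nM and compound 1 gives 32000 nM; compound 2 therefore holds the lower of the two numbers, and the gap between the two lies beyond the scatter of repeated measurements. For the measured compounds named here, the two compounds differ in more than one place, so no single structural step connects them; the two values only show that compound 2 is tolerated less than compound 1.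

Compound 3, `NC(=S)Nc1cccc(OCCCCCOc2cccc(C(=O)c3ccccc3)c2)c1`, is not yet measured in this assay. Relative to compound 2 the change is benzoyl in place of phenyl on an aromatic carbon. Going by the values given here, no measured pair in this set isolates such a change, so the direction of the step is open. With the rest of the molecule unchanged, the step from compound 2 to compound 3 is expected to be small, estimated at a 1.2-fold higher number from compound 2 to compound 3 (0.06 log units; within the scatter), within or close to the scatter. Compound 3 is thus expected to give 15000 nM, with a range of 5000 nM to 45000 nM.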

Compound 3, half-maximal cytotoxic concentration: 13000 nM
For compound 3 the middle estimate is 1.2-fold (0.06 log units) above the measured one; the measured number falls inside the stated range.
By their numbers in this assay, from the lowest: compounds 2 and 3 (each within the scatter of the next); then compound 1.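

Benzoyl in place of phenyl on an aromatic carbon, meta to a large group, gives the first single-place step in the series. In this assay, for the compounds shown here, this step reads as no change at the digits printed from compound 2 to compound 3 (within the scatter) and is the only reading so far at this position. It shows that the position can carry benzoyl, with 8 heavy atoms, a double bond outside the aromatic ring and 1 hydrogen-bond acceptor, in place of phenyl, with 6 heavy atoms and 0 hydrogen-bond acceptors, without a step beyond the scatter. No available data bear on the reason for this reading.

This single step cannot show whether the same holds for other groups at this position, such as an amine or a carboxylic acid, or whether a longer chain between the two aromatic ends would leave the reading within the scatter. Steps from compound 1 to compound 2 or compound 3 cannot be read, as those pairs differ in more than one place, so the contribution of each of those differences to tolerance in the cells remains open.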